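This account rests on a few compounds, and the source may have more. Where it says the series, first, only, none or still open, it means among the compounds named here.

Working notes on the series. Two amides sharing the core of compound 1 have been measured, and they differ only in where the amide sits on that core. Compound 1 `CCCCCCCC(=O)Nc1cccc(-c2ccccc2)c1` gives -4% in an in vitro assay on BTI-TN-5B1-4 cells for inhibition of sterol O-acyltransferase 2 (Homo sapiens), tested at 50 uM; a higher number here means more inhibition at the concentration tested (going by the name of the read-out), a lower number less inhibition. Compound 2 `CCCCCCCC(=O)Nc1ccc(-c2ccccc2)cc1` gives 11% in this assay. Compound 1 thus holds the lower of the two numbers, with compound 2 standing higher by more than the usual scatter. Compound 3 `CCCCCCCCC(=O)Nc1cccc(-c2ccccc2)c1` has not yet been measured and differs from compound 1 by methyl in place of hydrogen on a saturated chain carbon, seven bonds along the chain from a carbonyl carbon. The chain of compound 1 is kept and grows by one carbon at its far end. For the measured compounds named here, no measured pair carries a change of this kind, so no step on record can be set beside it. The expected step is a number 4 percentage points higher from compound 1 to compound 3 (within the scatter), none beyond the scatter. Compound 3 is accordingly estimated at 0%, with a range from -15% to 15%.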

Compound 3, a percentage reported as inhibition, at one concentration (the size of the read-out at that concentration, not a potency): -6%
The estimate for compound 3 lay 6 percentage points above the measured number, and the stated range covers the measured number.
By their numbers in this assay, from the lowest: compounds 3 and 1 (each within the scatter of the next); then compound 2.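

Methyl in place of hydrogen on a saturated chain carbon, seven bonds along the chain from a carbonyl carbon, is the only change at the far end of the chain that can be read in this assay, and the step is a number 2 percentage points lower from compound 1 to compound 3 (within the scatter). The earlier pair showed only a difference tied to where the amide sits on the shared core, whereas this pair shows that one more carbon at the far end of the chain of compound 1 stays within the scatter. No available data bear on a reason for this result.

As far as these compounds go, whether a longer chain, or a chain ending in a carboxylic acid or an amine, would go beyond the scatter at this position stays open. Also open, from the compounds shown here alone, is how the same added carbon reads with the amide placed as in compound 2.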